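Pyrazinyl Replacing Methyl on a Diaminonicotinonitrile Core

This account rests on a few compounds, and the source may have more. Where it says the series, first, only, none or still open, it means among the compounds named here.

The study tracks solubility across three closely related compounds sharing one fused bicyclic core. Compound 1 `CC(C)c1ncc2c(N)c(C#N)c(N)nc2n1` reaches only the upper limit of a physicochemical assay for solubility, in phosphate buffer, with a stated time of 18 h (on this read-out lower numbers stand for lower solubility and higher numbers for higher solubility), a limit and not a number, at > 1000000 nM. For the measured compounds named here, compound 2 `Cc1nc(C(C)(C)C)nc2nc(N)c(C#N)c(N)c12` gives the single numeric value in this assay, 37000 nM, and so stands alone as the one compound whose solubility is actually quantified. Compound 1, by contrast, sits at the limit of > 1000000 nM in this assay, at which 1 of the 2 values shown sits.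

Compound 3 `CC(C)(C)c1nc(-c2cnccn2)c2c(N)c(C#N)c(N)nc2n1` differs from compound 2 in one place: pyrazin-2-yl in place of methyl on an aromatic carbon. Going by the values given here, no step between measured compounds is available to calibrate this change, so any expectation rests on the structures alone. A ring of six heavy atoms with two nitrogen acceptors takes the place of a single carbon, and the expected outcome is a moderate loss of solubility, a step that reaches somewhat beyond the scatter, in the direction of lower numbers. Compound 3 is therefore estimated at 12000 nM, within a range from 2500 nM to 60000 nM, which corresponds to an expected step of a 3.1-fold lower number from compound 2 to compound 3 (0.49 log units; beyond the scatter).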

Compound 3, solubility: 86000 nM
Beside the measured number, compound 3's estimate is 7.2-fold (0.86 log units) below it; measured number outside the range, above it.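

For the compounds shown here, this is the first calibrated change at this position, the aromatic carbon next to the ring nitrogen and meta to a tert-butyl group: replacing methyl with pyrazin-2-yl gives a 2.3-fold higher number from compound 2 to compound 3 (0.37 log units; beyond the scatter) in this assay and shows that this position accepts a much larger group, one six-membered aromatic ring with 2 hetero atoms, without a fall in the number. The step is modest, yet its direction could not be seen from compound 1 and compound 2, which share no listed step. Nothing measured here accounts for this step, so the result stands as an observation without a stated cause.

The compounds shown leave open whether the step is particular to pyrazin-2-yl or would also appear with another group on this aromatic carbon, such as phenyl, pyridin-2-yl or an amine. As far as these compounds go, compound 1 gives > 1000000 nM in this assay as a limit and not a number, and it is joined to the other compounds by no single change, so its place stays open.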